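The source may report more compounds than this note shows. Statements on the series, on what has been measured and on what is new or still open speak of the compounds shown alone.

Measured in a functional assay on MCF7 cells (Homo sapiens) for inhibition, read by sulforhodamine B assay, with a stated time of 48 h; on this read-out higher numbers stand for weaker inhibition of growth and lower numbers for stronger inhibition of growth:
- compound 1 `S=C(N/N=C/c1cccs1)Nc1ccccc1`: 94600 nM
- compound 2 `S=C(N/N=C/c1cccs1)Nc1cccnc1`: > 100000 nM, a limit of the assay
- compound 3 `S=C(N/N=C/c1cccs1)Nc1cccc2ccccc12`: > 100000 nM, a limit of the assay

Among the measured compounds shown here, compound 1 holds the only true number among the three. For compound 2 and compound 3 the reading is the limit of > 100000 nM in this assay, at which 2 of the 3 values shown sit. Compound 4 `COc1ccc(NC(=S)N/N=C/c2cccs2)cc1` differs from compound 1 by methoxy in place of hydrogen on an aromatic carbon. For the measured compounds named here, no measured pair shows the size of such a change, so no step beyond the scatter is expected in this assay. That expectation starts from compound 1 at 94600 nM. The expected step of a 1.4-fold lower number from compound 1 to compound 4 (0.13 log units; within the scatter) is small. For compound 4 the estimated value is 70000 nM, with an expected range of 20000 nM to 130000 nM.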

Compound 4, concentration for 50% growth inhibition: > 100000 nM
Compound 4: only a limit was reported; the forecaster's own chance of this, stated with the estimate: 35%; middle value at least 1.4-fold (0.15 log units) from the limit.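

In this assay compound 4 gives > 100000 nM, which is a limit of the assay and not a number. Methoxy in place of hydrogen, para to a large group, thus brings no visible lowering of the number: the change gives an at least 1.0-fold higher number from compound 1 to compound 4 (0.02 log units; that floor lies within the scatter), and how far the true value lies from compound 1 cannot be read. This leaves the series with very little that can be compared: the limit of > 100000 nM in this assay, at which 3 of the 4 values shown sit.

Open, from the compounds shown here alone, is whether an amine, a carboxylic acid or a chlorine atom at this position would lower the number. Also open, going by these compounds, is what methoxy would do elsewhere on that ring.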